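Longer thioether chains in a chloromethyl ketone series

The compounds below may be only part of what the source reports. "The series", "measured", "known", "first", "only" and "open" are said of these compounds alone.

Measured compounds:
compound 1 `CCCCCCCSC[C@H](NC(C)=O)C(=O)CCl` with 4800 nM
compound 2 `CCCCCCCCSC[C@H](NC(C)=O)C(=O)CCl` with 5600 nM
compound 3 `CCCCCCCCCCCCCCSC[C@H](NC(C)=O)C(=O)CCl` with 8700 nM

In a functional assay on NALM-6 cells (Homo sapiens) (a higher number here means a weaker inhibitor, a lower number a stronger inhibitor), compound 1 gives 4800 nM, compound 2 gives 5600 nM and compound 3 gives 8700 nM. Compound 3 carries the highest number of the three, yet the steps that lead to it, a 1.8-fold higher number from compound 1 to compound 3 (0.26 log units; within the scatter) and a 1.6-fold higher number from compound 2 to compound 3 (0.19 log units; within the scatter), both sit within the scatter, as does a 1.2-fold higher number from compound 1 to compound 2 (0.07 log units; within the scatter), so no ordering among the three is secured. Compound 4 `CCCCCCCCCCCCCCCCSC[C@H](NC(C)=O)C(=O)CCl` differs from compound 3 by ethyl in place of hydrogen on a saturated chain carbon, ten or more bonds along the chain from a sulfur. The three earlier steps are of the same kind and none of them moved the number beyond the scatter, so for compound 4 the step of a 1.3-fold higher number from compound 3 to compound 4 (0.10 log units; within the scatter) is expected, with compound 4 estimated at 11000 nM in this assay, within a range of 5000 nM to 25000 nM.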

Compound 4, half-maximal inhibitory concentration: 16000 nM
Beside the measured number, compound 4's estimate is 1.5-fold (0.16 log units) below it; measured number inside the range.
By their numbers in this assay, from the lowest: compounds 1, 2, 3 and 4 (each within the scatter of the next, the first and the last beyond it).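

In this assay the thioether series now gives its first steps beyond the scatter: a 2.9-fold higher number from compound 2 to compound 4 (0.46 log units; beyond the scatter) and a 3.3-fold higher number from compound 1 to compound 4 (0.52 log units; beyond the scatter) are both modest, while the ethyl change alone (a 1.8-fold higher number from compound 3 to compound 4 (0.26 log units; within the scatter)) stays within it. Octyl or nonyl in place of hydrogen on this chain therefore does raise the number, though the rise can be read only between the ends of the set. Nothing available explains this shift.

The compounds shown leave open whether a longer chain would raise the number further, and whether a chain ending in a carboxylic acid or an amine would behave the same way.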